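A few compounds are considered here, and "the series" means these few. Any claim that something is new, unique, unknown or untested is made for them only; others in the source may bear on it.

Compound 1 `COc1cccc(CNCCCNc2ccnc3cc(Oc4ccccc4)ccc23)c1O` gives 317 10^-6 cm/s in an ADME assay for permeability, using PAMPA, with a stated time of 30 min, at pH 7.4 (on this read-out lower numbers stand for lower permeability and higher numbers for higher permeability), the higher of the two numbers measured, while compound 2 `COc1cccc(CNCCCNc2ccnc3cc(-c4ccc(C(C)(C)C)cc4)ccc23)c1O` gives 237 10^-6 cm/s in this assay, the step being a 1.3-fold lower number from compound 1 to compound 2 (0.13 log units; within the scatter). Compound 3 `COc1ccc(F)cc1CNCCCNc1ccnc2cc(Oc3ccccc3)ccc12` differs from compound 1 in one place: 5-fluoro-2-methoxyphenyl in place of 2-hydroxy-3-methoxyphenyl on a saturated chain carbon bound to an amine nitrogen. Within the data shown here, the only measured step, from compound 1 to compound 2, concerns another part of the structure and was within the scatter, so it gives no direct guide. For compound 3 a number close to that of compound 1 is expected, a 1.1-fold higher number from compound 1 to compound 3 (0.04 log units; within the scatter), with an estimate of 350 10^-6 cm/s and a range of 200 10^-6 cm/s to 600 10^-6 cm/s.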

Compound 3, apparent permeability: 317 10^-6 cm/s
Estimate against measurement, compound 3: 1.1-fold (0.04 log units) above; the measured number falls inside the stated range.
By their numbers in this assay, from the lowest: compounds 2, 1 and 3 (each within the scatter of the next).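

Placing 5-fluoro-2-methoxyphenyl where 2-hydroxy-3-methoxyphenyl stood gives no change at the digits printed from compound 1 to compound 3 (within the scatter) in this assay, the first reading at this position. The read-out thus stays level even though the group entering has 0 hydrogen-bond donors and 1 hydrogen-bond acceptor, against 1 and 2 in the group leaving. Nothing available explains this result. Because the swap alters several atoms at once, the separate contributions of the fluorine and the hydroxyl remain unresolved. Also open, from the compounds shown here alone, is how a carboxylic acid on this ring, or a longer chain, would read.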